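Swapping a Sulfonyl Side Chain for an Amino Group

A few compounds are considered here, and "the series" means these few. Any claim that something is new, unique, unknown or untested is made for them only; others in the source may bear on it.

In an ADME assay on microsomes from liver (Mus musculus) for metabolic stability, read by LC-MS, using NADPH, with a stated time of 30 min, tested at 0.1 uM (a lower number here means that less of the compound is left, a higher number that more of the compound is left), compound 1 `O=S(=O)(NCCN1CCCC1)c1cccc(-c2ccc3nccc(-c4ccnc(C(F)(F)F)c4)c3n2)c1` gives 8%, and compound 2 `O=S(=O)(CCO)c1cccc(-c2ccc3nccc(-c4ccncc4)c3n2)c1` gives 52%. Compound 2 therefore stands as the higher of the two measured compounds, and the gap between them lies beyond the usual scatter.

Compound 3 `Nc1cccc(-c2ccc3nccc(-c4ccncc4)c3n2)c1` is the next to consider. It keeps the rest of compound 2 and changes a single group: amino in place of (2-hydroxyethyl)sulfonyl on an aromatic carbon.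

Among the measured compounds shown here, no two measured compounds differ in just one place, so no measured step can guide this prediction, and any forecast remains tentative. For the measured compounds named here, with only two values available, compound 2 at 52% is the natural starting point, while compound 1 at 8% shows how far the read-out can lie under it. A moderate fall in this assay, beyond the scatter, seems more likely than a rise. The expected change is a number 22 percentage points lower from compound 2 to compound 3 (beyond the scatter). For compound 3 the estimated value is 30%, with an expected range from 10% to 55%.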

Compound 3, percent of the compound remaining: 54%
Compound 3: middle estimate off by 24 percentage points, on the low side; measured number inside the range.
By their numbers in this assay, from the lowest: compound 1; then compounds 2 and 3 (each within the scatter of the next).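

In this assay, putting amino in place of (2-hydroxyethyl)sulfonyl on an aromatic carbon gives a number 2 percentage points higher from compound 2 to compound 3 (within the scatter). Among the compounds shown here, this is the first direct comparison at this position, and it does not separate the two groups, even though amino has one heavy atom and the group it replaces has six, including the sulfur and all three oxygens. With the rest of the molecule held constant, the read-out therefore does not depend on the sulfonyl side chain in this one pair, but nothing measured here explains why.

As far as these compounds go, whether a carboxylic acid, a methoxy group or a longer chain such as 2-aminoethyl at this position would also stay within the scatter of compound 2 and compound 3 remains open. It is also unknown whether amino would give a similar result on the core of compound 1, which carries a trifluoromethyl group, since a single pair cannot show how far this result extends to other members of the series.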